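Benzyl in Place of Methyl on a Sulfonamide Urea

A few compounds are considered here, and "the series" means these few. Any claim that something is new, unique, unknown or untested is made for them only; others in the source may bear on it.

Measured compounds:
compound 1 `CNS(=O)(=O)c1ccc(NC(=O)NCc2ccncc2)cc1`: 3230 nM
compound 2 `CCOC(=O)c1ccc(NC(=O)NCc2cc[nH]n2)cc1`: 69000 nM
compound 3 `CCOC(=O)c1ccc(N/C(=N\C#N)NCc2ccncc2)cc1`: 41400 nM

In an assay on isolated protein for activation of Nicotinamide phosphoribosyltransferase (Homo sapiens) (a higher number here means that more compound is needed for the effect, a lower number that less compound is needed), compound 1 gives the lowest of the three numbers; compound 3 sits well above it and compound 2 further still, both gaps being beyond the usual scatter. Compound 4 `O=C(NCc1ccncc1)Nc1ccc(S(=O)(=O)NCc2ccccc2)cc1` differs from compound 1 in one place: phenyl in place of hydrogen on a saturated chain carbon bound to a sulfonamide nitrogen. Within the data shown here, no measured pair shows this change, so the size of its step is open. The sulfonamide end of compound 1 is the only part of the set that varies in this way, and a modest move towards a lower number is anticipated rather than none. Compound 4 is therefore expected to reach 1000 nM in this assay, within a range from 300 nM to 3500 nM, which would mean an estimated step of a 3.2-fold lower number from compound 1 to compound 4 (0.51 log units; beyond the scatter).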

Compound 4, half-maximal effective concentration: 102 nM
Compound 4: middle estimate off by 9.8-fold (0.99 log units), on the high side, and the stated range ends above it.
By their numbers in this assay, from the lowest: compound 4; then compound 1; then compounds 3 and 2 (each within the scatter of the next).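

Turning methyl into benzyl at the sulfonamide end gives a 32-fold lower number from compound 1 to compound 4 (1.50 log units; beyond the scatter) in this assay, a large step beyond the scatter. Among these compounds, this position therefore accepts a phenyl ring and the number responds strongly to it, which the earlier compounds, none of them varied here, could not show. Nothing available explains the size of this step. On these data alone, it remains open whether a longer chain such as phenethyl, or a benzyl carrying a fluorine or a methoxy group, would move the number further. As far as these compounds go, whether an amine or a carboxylic acid on the phenyl ring would be accepted also remains open.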